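Replacing the aryl group on the amide carbonyl of compound 1

The source may hold more compounds than are shown below. What is called first, only, known or untested is meant among the compounds shown, and "the series" means these compounds.

In a functional assay on MCF7 cells (Homo sapiens) for antiproliferative activity (on this read-out higher numbers stand for weaker inhibition and lower numbers for stronger inhibition), compound 1 (`O=C(Nc1ccc(O)c2c(=O)cc(-c3ccccc3Cl)oc12)c1ccc(Cl)c(Cl)c1`) gives 15000 nM and compound 2 (`Cc1ccc(C(=O)Nc2c(O)cc(O)c3c(=O)cc(-c4ccccc4Cl)oc23)cc1`) gives 9700 nM and compound 3 (`COc1ccc(C(=O)Nc2c(O)cc(O)c3c(=O)cc(-c4ccccc4Cl)oc23)cc1`) gives 13000 nM with all three within the scatter of one another. Compound 4 (`C[C@@H](NC(=O)OC(C)(C)C)C(=O)Nc1ccc(O)c2c(=O)cc(-c3ccccc3Cl)oc12`) carries 1-((tert-butoxycarbonyl)amino)ethyl in place of 3,4-dichlorophenyl on a carbonyl carbon. Going by the values given here, the only measured step (a 1.3-fold higher number from compound 2 to compound 3 (0.13 log units; within the scatter)) is methoxy in place of methyl on an aromatic carbon and stays within the scatter. Among the compounds with values here, no measured compound lacks an aromatic ring at this carbonyl carbon, so the evidence is thin. No step beyond the scatter is expected in this assay and the estimated step (a 1.2-fold higher number from compound 1 to compound 4 (0.08 log units; within the scatter)) leaves the direction open. For compound 4 the estimated value is 18000 nM with an expected range from 7000 nM to 50000 nM on this read-out.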

Compound 4, half-maximal inhibitory concentration: 5500 nM
Compound 4: middle estimate off by 3.3-fold (0.51 log units), on the high side; the whole stated range lies above it.
By their numbers in this assay, from the lowest: compounds 4, 2, 3 and 1 (each within the scatter of the next, the first and the last beyond it).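

In this assay the carbonyl carbon whose other neighbour is the amide-type nitrogen does not need an aromatic ring: 1-((tert-butoxycarbonyl)amino)ethyl in place of 3,4-dichlorophenyl gives a modest gain (a 2.7-fold lower number from compound 1 to compound 4 (0.44 log units; beyond the scatter)). Going by these compounds alone, this is the first step beyond the scatter. No measurement at hand accounts for it.

Open, from the compounds shown here alone, is whether the gain rests on the tert-butoxycarbonyl group or on the ethyl chain with its defined stereocentre. The free amine, 1-aminoethyl, and the opposite stereoisomer would separate these.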